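The source may hold more compounds than are shown below. What is called first, only, known or untested is meant among the compounds shown, and "the series" means these compounds.

Compound 1 `O=C(NCc1ccccc1)c1cccn1-c1ccc2c(c1)B(O)OC2`, compound 2 `CNC(=O)c1cccn1-c1ccc2c(c1)B(O)OC2` and compound 3 `O=C(c1ccc(F)cc1)c1ccn(-c2ccc3c(c2)B(O)OC3)c1` share one core and were run in an ADME assay on L929 cells (Mus musculus) for cytotoxicity, read by resazurin assay, with a stated time of 72 h; a lower number here means a stronger inhibitor, a higher number a weaker inhibitor. In this assay compound 1 gives > 10 ug/mL, which is a limit of the assay. Compound 2 gives > 10 ug/mL, likewise a limit. Compound 3 gives > 10 ug/mL, again a limit. Among the compounds with values here, the only measured step, a step that the two limits leave unreadable from compound 1 to compound 2, therefore has no readable size. Compound 3 stands at the limit of > 10 ug/mL in this assay, at which 3 of the 3 values shown sit, alongside the other two values. Compound 4 `COc1ccc(C(=O)c2ccn(-c3ccc4c(c3)B(O)OC4)c2)cc1` differs from compound 3 by methoxy in place of fluoro on an aromatic carbon. Within the data shown here, no measured step bears on this change, since the one from compound 1 to compound 2 is unreadable; no step beyond the scatter is expected, the estimated step being a step that the limit leaves unreadable from compound 3 to compound 4. Compound 4 is therefore expected at 20 ug/mL, within 8 ug/mL to 60 ug/mL, most probably reported again as a limit.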

Compound 4, half-maximal inhibitory concentration: > 10 ug/mL
Compound 4 was reported as a limit; the forecaster's own chance of this, stated with the estimate: 85%; the middle value is on the limit's open side.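

No new step can be read: compound 3 and compound 4 both stand only as limits in this assay, leaving methoxy in place of fluoro without a readable size. The compounds shown leave open at what concentration, if any, cytotoxicity becomes measurable.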